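The source may report more compounds than this note shows. Statements on the series, on what has been measured and on what is new or still open speak of the compounds shown alone.

Of the compounds shown here, three that share one core have been tested in a functional assay on Ehrlich cells (Mus musculus) for cytotoxicity, tested at 10 ug/mL; a higher number here means a stronger effect of the compound at the concentration tested, a lower number a weaker effect. Compound 1, `COc1cc(N2C(N)=C(C#N)C(c3ccc([N+](=O)[O-])cc3)C3=C2CC(C)(C)CC3=O)cc(OC)c1OC`, gives 10% in this assay. Compound 2, `COc1cc(N2C(N)=C(C#N)C(/C=C/c3ccccc3)C3=C2CC(C)(C)CC3=O)cc(OC)c1OC`, gives 10%. Compound 3, `COc1cc(N2C(N)=C(C#N)C(c3ccccc3O)C3=C2CC(C)(C)CC3=O)cc(OC)c1OC`, gives 0%. Compound 2 thus stands level with compound 1 at the digits shown, the two together being the highest of the three numbers, while the step of a number 10 percentage points lower from compound 2 to compound 3 (within the scatter) and the step of a number 10 percentage points lower from compound 1 to compound 3 (within the scatter) both lie within the scatter of repeated measurements, so on these numbers no compound can be called more or less active than another.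

Compound 4, `COc1cc(N2C(N)=C(C#N)C(c3c(O)ccc4ccccc34)C3=C2CC(C)(C)CC3=O)cc(OC)c1OC`, has not yet been measured. It differs from compound 2 in one place: 2-hydroxynaphthalen-1-yl in place of 2-phenylethenyl on a saturated ring carbon. The measured step that bears most directly on this change is a number 10 percentage points lower from compound 2 to compound 3 (within the scatter), where a 2-hydroxyphenyl group took the place of the same 2-phenylethenyl group on the same saturated ring carbon; the group entering in compound 4 likewise carries a hydroxyl, joined to a second aromatic ring. Because the step of a number 10 percentage points lower from compound 2 to compound 3 (within the scatter) stayed within the scatter, compound 4 is expected to give a low number as well, and the step of a number 5 percentage points lower from compound 2 to compound 4 (within the scatter) is expected to remain within the scatter. The estimate for compound 4 is 5%, with a range from 0% to 20%.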

Compound 4, a percentage reported as activity, at one concentration (the size of the read-out at that concentration, not a potency): 2%
Beside the measured number, compound 4's estimate is 3 percentage points above it, and the stated range covers the measured number.
By their numbers in this assay, from the lowest: compounds 3, 4, 1 and 2 (each within the scatter of the next).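

In this assay, among these compounds, this is the first step at the saturated ring carbon that adds a second aromatic ring to a hydroxyl-bearing group, and the read-out stays within the scatter (a number 2 percentage points higher from compound 3 to compound 4 (within the scatter)). The same holds when 2-hydroxynaphthalen-1-yl replaces the two groups without a hydroxyl (a number 8 percentage points lower from compound 2 to compound 4 (within the scatter) and a number 8 percentage points lower from compound 1 to compound 4 (within the scatter)), so the four groups now seen at this position cannot be ranked, even though they include one or two aromatic rings and a double bond outside any ring in 2-phenylethenyl. No measurement is available that could explain this result.

The compounds shown leave open whether a quite different group on this carbon, such as a 4-carboxyphenyl, a simple aminoalkyl chain or a small methyl, would move the read-out beyond the scatter. They also leave open what happens when the 3,4,5-trimethoxyphenyl group or the amino group on the shared core is replaced, and, with only one concentration tested, how potent any of these compounds would be.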